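Urea Aryl Swap Without Precedent in This Set

This account rests on a few compounds, and the source may have more. Where it says the series, first, only, none or still open, it means among the compounds named here.

Measured compounds:
compound 1 `COc1cc(NC(=O)Nc2cc(Nc3ccc(C(C)(C)C)cc3)ncn2)cc(OC)c1`: 17.5%
compound 2 `COc1cc(NC(=O)Nc2cc(Nc3ccc(C)c(F)c3)ncn2)cc(OC)c1`: 30.6%
compound 3 `COc1cc(NC(=O)Nc2cc(Nc3cc(F)ccc3OC)ncn2)cc(OC)c1`: 38%

In a functional assay on NCI-H520 cells (Homo sapiens) for inhibition, read by MTT assay, with a stated time of 48 h, tested at 10 uM (on this read-out lower numbers stand for less inhibition and higher numbers for more inhibition at the one concentration tested (going by the name of the read-out)), compound 1 stands lowest of the three: the nearest, compound 2, lies a number 13.1 percentage points higher from compound 1 to compound 2 (beyond the scatter) away, and the furthest, compound 3, lies a number 20.5 percentage points higher from compound 1 to compound 3 (beyond the scatter) away. Compound 4 `CC(C)(C)c1ccc(Nc2cc(NC(=O)Nc3c(Cl)cccc3Cl)ncn2)cc1` differs from compound 1 by 2,6-dichlorophenyl in place of 3,5-dimethoxyphenyl on an amide-type nitrogen. All three measured steps vary the group on the aromatic nitrogen instead, so none of them bears on this change; the step from compound 2 to compound 3, a number 7.4 percentage points higher from compound 2 to compound 3 (within the scatter), is uninformative here as well. With no guide, only a small step in this assay can be expected for compound 4, a number 6.5 percentage points higher from compound 1 to compound 4 (within the scatter), and in no sure direction. Compound 4 is estimated at 24%, within 5% to 48%.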

Compound 4, a percentage reported as inhibition, at one concentration (the size of the read-out at that concentration, not a potency): 22%
Compound 4: middle estimate off by 2 percentage points, on the high side; the measured number falls inside the stated range.
By their numbers in this assay, from the lowest: compounds 1, 4, 2 and 3 (each within the scatter of the next, the first and the last beyond it).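

In this assay, going by these compounds alone, the exchange of 3,5-dimethoxyphenyl for 2,6-dichlorophenyl on the amide-type nitrogen gives the first step at this place, a number 4.5 percentage points higher from compound 1 to compound 4 (within the scatter). With the 4-(tert-butyl)phenyl group held fixed, the two aryl groups therefore cannot be told apart on this read-out. Nothing on hand accounts for this result. Going by these compounds, it remains open whether the same exchange would read alike alongside the groups of compound 2 or compound 3. Also open, on these data alone, is what a phenyl carrying an amine or a carboxylic acid would give on this nitrogen.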